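This account rests on a few compounds, and the source may have more. Where it says the series, first, only, none or still open, it means among the compounds named here.

In a functional assay on MDA-MB-436 cells (Homo sapiens) for antiproliferative activity, read by MTT assay, with a stated time of 48 h (on this read-out higher numbers stand for weaker inhibition and lower numbers for stronger inhibition), compound 1 `C=CS(=O)(=O)N1CCN(c2ncnc3sc(-c4ccc(OC)cc4)cc23)CC1` gives 28400 nM and compound 2 `C=CS(=O)(=O)N1CCN(c2ncnc3sc(-c4cn(S(=O)(=O)c5ccccc5)c5ccccc45)cc23)CC1` gives 38000 nM. Compound 3 `CN1CCN(c2ccc(-c3cc4c(N5CCN(S(=O)(=O)N6CCCCC6)CC5)ncnc4s3)cc2)CC1` gives 7570 nM, the lowest of the three numbers, and its gaps to both others lie beyond the scatter. Compound 4 `CN1CCN(c2ccc(-c3cc4c(N5CCN(C(=O)Nc6ccc(C#N)cc6)CC5)ncnc4s3)cc2)CC1` keeps the rest of compound 3 but carries (4-cyanophenyl)carbamoyl in place of (piperidin-1-yl)sulfonyl on an amine nitrogen in a ring. Within the data shown here, no measured pair changes only this place, so the data offer no direct guide and the expectation stays close to compound 3. The expected step, a 1.3-fold lower number from compound 3 to compound 4 (0.10 log units; within the scatter), is small, slightly toward stronger inhibition and not beyond the scatter. For compound 4 the estimated value is 6000 nM, with an expected range from 1500 nM to 24000 nM.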

Compound 4, half-maximal inhibitory concentration: 5010 nM
For compound 4 the middle estimate is 1.2-fold (0.08 log units) above the measured one; the range from low to high includes it.
By their numbers in this assay, from the lowest: compounds 4 and 3 (each within the scatter of the next); then compounds 1 and 2 (each within the scatter of the next).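

Placing (4-cyanophenyl)carbamoyl in place of (piperidin-1-yl)sulfonyl on an amine nitrogen in a ring gives a 1.5-fold lower number from compound 3 to compound 4 (0.18 log units; within the scatter) in this assay. This position therefore carries two quite different groups, one with a six-membered non-aromatic ring and one with a six-membered aromatic ring and a hydrogen-bond donor, and the two compounds cannot be told apart. Nothing available explains this result.

As far as these compounds go, whether a small group such as acetyl or methyl on this nitrogen would give a similar number remains open. So does the part played by the nitrile, which a plain phenylcarbamoyl group would test.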